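This account rests on a few compounds, and the source may have more. Where it says the series, first, only, none or still open, it means among the compounds named here.

Working notes on the series. In an ADME assay on MDCK cells (Canis lupus familiaris) for cytotoxicity (a lower number here means that less compound is tolerated, a higher number that more compound is tolerated), compound 1 (`O=[N+]([O-])C1=NNc2nc(C(F)(F)F)nn2C1c1ccc(O)c(O)c1`) gives 183000 nM and compound 2 (`CSc1nc2n(n1)C(c1ccc(O)c(O)c1)C([N+](=O)[O-])=NN2`) gives 362000 nM. These two numbers lie within the scatter of each other, so compound 2 stands level with compound 1, and no ranking can be drawn from them.

Compound 3 (`CSc1nc2n(n1)C(c1ccc(O)c(O)c1O)C([N+](=O)[O-])=NN2`) keeps the methylsulfanyl group of compound 2 and differs from it as follows: hydroxy in place of hydrogen on an aromatic carbon. In words, this is hydroxy in place of hydrogen on an aromatic carbon.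

For the measured compounds named here, no measured step covers this change. The only one available is a 2.0-fold higher number from compound 1 to compound 2 (0.30 log units; within the scatter), which is methylsulfanyl in place of trifluoromethyl on an aromatic carbon, at a different place in the structure. It bears on the new change only indirectly, showing one substitution in this series that stayed within the scatter. No direction can be taken from it, and the wide range reflects this thin basis.

The expected change in this assay is a 1.2-fold lower number from compound 2 to compound 3 (0.08 log units; within the scatter), which means no shift beyond the scatter is expected. In this assay, the estimated value for compound 3 is 300000 nM, with an expected range of 120000 nM to 700000 nM.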

Compound 3, half-maximal cytotoxic concentration: 196000 nM
Compound 3: middle estimate off by 1.5-fold (0.18 log units), on the high side; the measured number falls inside the stated range.
By their numbers in this assay, from the lowest: compounds 1, 3 and 2 (each within the scatter of the next).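

In this assay, hydroxy in place of hydrogen on the six-membered aromatic ring, ortho to a hydroxy group and ortho to a large group, gives a 1.8-fold lower number from compound 2 to compound 3 (0.27 log units; within the scatter). For the compounds shown here, this is the first reading on that ring, since the earlier step concerned only the exchange of trifluoromethyl for methylsulfanyl elsewhere in the structure, and it shows that this added hydroxy, with the methylsulfanyl group held constant, leaves the number within the scatter. No information at hand bears on what lies behind this result.

The compounds shown leave open whether this place tolerates something other than hydroxy in the same way, such as a methoxy group, a fluorine atom or an amine, and whether the added hydroxy would give a similar result alongside trifluoromethyl rather than methylsulfanyl. Going by these compounds alone, they also leave open what happens at the nitro group of the shared core, where a nitrile or a carboxylic acid would give a first reading at that place.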